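Fused group swap at one aromatic carbon

The compounds below may be only part of what the source reports. "The series", "measured", "known", "first", "only" and "open" are said of these compounds alone.

Values so far in a physicochemical assay for lipophilicity, using the shake flask method, measured as octanol-water partition, at pH 7.4 (a lower number here means a more polar compound, a higher number a more lipophilic compound), for the series
- compound 1 `CC(=O)N[C@@H]1CCC[C@H](C(=O)Nc2cc(-c3cnc4n3CCCC4)c(Cl)cn2)C1` gives 2.7
- compound 2 `CC(=O)N[C@@H]1CCC[C@H](C(=O)Nc2cc(-c3cnc4n3CCC4)c(Cl)cn2)C1` gives 2.6
- compound 3 `CC(=O)N[C@@H]1CCC[C@H](C(=O)Nc2cc(-c3cnn4c3CN(C)CC4)c(Cl)cn2)C1` gives 2.1

Compound 3 stands lowest of the three, with compound 2 and compound 1 both higher by more than the scatter. Compound 4 `CC(=O)N[C@@H]1CCC[C@H](C(=O)Nc2cc(-c3cnn4c3CC(C)(C)C4)c(Cl)cn2)C1` is next, and its change from compound 3 is a group of 10 heavy atoms (8 carbon, 2 nitrogen; one five-membered non-aromatic ring with 1 hetero atom, one five-membered aromatic ring with 2 hetero atoms) in place of a group of 10 heavy atoms (7 carbon, 3 nitrogen; one five-membered aromatic ring with 2 hetero atoms, one six-membered non-aromatic ring with 2 hetero atoms), on an aromatic carbon on an aromatic carbon, ortho to a chloro group. Two modest steps bring in the group that compound 4 gives up, namely a number 0.60 log units lower from compound 1 to compound 3 (beyond the scatter) and also a number 0.50 log units lower from compound 2 to compound 3 (beyond the scatter) in the same direction. Exchanging the six-membered non-aromatic ring for a five-membered one gave a number 0.10 log units lower from compound 1 to compound 2 (within the scatter) and so adds no size of its own. Within the data shown here, no measured compound carries the entering group, so the read-across is indirect. Reading those two modest steps backwards, a rise of similar size is expected in this assay with the expected step being a number 0.70 log units higher from compound 3 to compound 4 (beyond the scatter) for this change. For compound 4 the estimated value is 2.8 with an expected range of 2.4 to 3.2 in this measurement.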

Compound 4, distribution coefficient: 3.8
Beside the measured number, compound 4's estimate is 1.00 log units below it, and the stated range ends below it.
By their numbers in this assay, from the lowest: compound 3; then compounds 2 and 1 (each within the scatter of the next); then compound 4.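

In this assay, among these compounds, this aromatic carbon, ortho to a chloro group, proves far more responsive to the fused group than the earlier compounds showed, with a number 1.70 log units higher from compound 3 to compound 4 (beyond the scatter) even though both groups have 10 heavy atoms; the entering group has 8 carbon and 2 nitrogen in place of 7 carbon and 3 nitrogen. The other two steps are also large, a number 1.20 log units higher from compound 2 to compound 4 (beyond the scatter) and a number 1.10 log units higher from compound 1 to compound 4 (beyond the scatter), so the gap is not specific to the group of compound 3. Nothing measured here accounts for the size of these steps.

On these data alone, the swap alters ring size and atom content together, so the share of each stays open. As far as these compounds go, how this assay would respond to a hydroxyl or a carboxylic acid on the fused group also remains unknown.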